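The source may hold more compounds than are shown below. What is called first, only, known or untested is meant among the compounds shown, and "the series" means these compounds.

Of the compounds shown here, two of a shared core have been tested in an ADME assay on THP-1 cells (Homo sapiens) for cytotoxicity, read by MTT assay, tested at 50 ug/mL; on this read-out higher numbers stand for more inhibition at the one concentration tested (going by the name of the read-out) and lower numbers for less inhibition. Compound 1 `O=[N+]([O-])c1ccc(-c2csc(N/N=C/c3ccc(-n4ccnc4)cc3)n2)cc1` carries a nitro group on one of its outer rings and an imidazole on the other, and in this assay compound 1 gives 16.4%. Compound 2 `Brc1ccc(-c2csc(N/N=C/c3ccc(-n4cncn4)cc3)n2)cc1` carries instead a bromo group and a triazole, and in this assay compound 2 gives 32.6%. Compound 2 thus stands highest of the two numbers, and its nearest neighbour is compound 1, whose number lies beyond the usual scatter below it. The two compounds differ in two places at once. Their values alone say nothing about which change matters.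

Compound 3 `O=[N+]([O-])c1ccc(-c2csc(N/N=C/c3ccc(-n4cncn4)cc3)n2)cc1` keeps the triazole of compound 2 and introduces the change (nitro in place of bromo on an aromatic carbon). For the measured compounds named here, no measured pair shows this step on its own. Going by the values given here, since compound 1, the only nitro-bearing compound, gives 16.4%, a step downward that may reach past the scatter is expected. Compound 3 is therefore estimated at 22% in this assay, with a likely range from 8% to 38%, which would mean a step of a number 10.6 percentage points lower from compound 2 to compound 3 (beyond the scatter).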

Compound 3, a percentage reported as inhibition, at one concentration (the size of the read-out at that concentration, not a potency): 12.9%
For compound 3 the middle estimate is 9.1 percentage points above the measured one, and the stated range covers the measured number.
By their numbers in this assay, from the lowest: compounds 3 and 1 (each within the scatter of the next); then compound 2.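

With the triazole held fixed, the change from 4-bromophenyl to 4-nitrophenyl can now be read on its own: in this assay, nitro in place of bromo on this aromatic carbon, para to a large group, gives a number 19.7 percentage points lower from compound 2 to compound 3 (beyond the scatter). For the compounds shown here, with nitro held fixed, 1H-1,2,4-triazol-1-yl in place of 1H-imidazol-1-yl gives a number 3.5 percentage points lower from compound 1 to compound 3 (within the scatter), so at the other end of the molecule this change cannot be told apart from ordinary variation between repeated measurements, and of the two single changes now visible, only the one from bromo to nitro gives a clear step. The data shown offer no measurement that would explain why either step has the size it does.

From the compounds shown here alone, the triazole and imidazole comparison is available only with nitro on the opposite ring, so it remains open whether the step would stay as small with bromo in that place. Going by these compounds, with only bromo and nitro compared at this position, it also remains open how an amine or a carboxylic acid there would read, and so whether the step is particular to nitro or part of a wider trend.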